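The source may hold more compounds than are shown below. What is called first, only, known or untested is meant among the compounds shown, and "the series" means these compounds.

Of the compounds shown here, three sharing one core have been measured in a functional assay on HT-29 cells (Homo sapiens) for cytotoxicity, read by MTT assay, with a stated time of 24 h; on this read-out higher numbers stand for weaker inhibition and lower numbers for stronger inhibition: compound 1 `Cn1c(-c2ccc(NC(=O)CSc3nc4ccccc4o3)cc2)nc(-c2ccccc2)c1-c1ccccc1` gives 11 ug/mL, compound 2 `Cn1c(-c2ccc(NC(=O)CSc3nc4ccccc4s3)cc2)nc(-c2ccccc2)c1-c1ccccc1` gives 18 ug/mL, and compound 3 `Cn1nnnc1SCC(=O)Nc1ccc(-c2nc(-c3ccccc3)c(-c3ccccc3)n2C)cc1` gives 1.6 ug/mL. Compound 3 has the lowest of the three numbers, and its steps to both others lie beyond the scatter. The next structure, compound 4 `CN1CCN(CC(=O)Nc2ccc(-c3nc(-c4ccccc4)c(-c4ccccc4)n3C)cc2)CC1`, is altered on the same arm: 4-methylpiperazin-1-yl in place of (1-methyl-1H-tetrazol-5-yl)sulfanyl on a saturated chain carbon bound to a carbonyl carbon. Here 4-methylpiperazin-1-yl stands in place of (1-methyl-1H-tetrazol-5-yl)sulfanyl on a saturated chain carbon bound to a carbonyl carbon, so the sulfur leaves as well.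

Going by the values given here, the steps that bear on this change are those that exchange the group on the sulfur. There is a modest one, a 6.9-fold lower number from compound 1 to compound 3 (0.84 log units; beyond the scatter), and a large one, an 11-fold lower number from compound 2 to compound 3 (1.05 log units; beyond the scatter), while a 1.6-fold higher number from compound 1 to compound 2 (0.21 log units; within the scatter) stays within the scatter. None of them removes the sulfur or brings in a non-aromatic ring, so they guide the estimate only loosely. Compound 3, at 1.6 ug/mL, sits lowest of the set, so a modest step toward a higher number is expected in this assay. The estimate corresponds to an expected 3.1-fold higher number from compound 3 to compound 4 (0.49 log units; beyond the scatter). For compound 4 the estimated value is 5 ug/mL, with an expected range of 1.2 ug/mL to 20 ug/mL.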

Compound 4, half-maximal inhibitory concentration: 35.5 ug/mL
Compound 4: middle estimate off by 7.1-fold (0.85 log units), on the low side, outside the stated range (above it).
By their numbers in this assay, from the lowest: compound 3; then compounds 1, 2 and 4 (each within the scatter of the next, the first and the last beyond it).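

In this assay, going by these compounds alone, the replacement of (1-methyl-1H-tetrazol-5-yl)sulfanyl by 4-methylpiperazin-1-yl on a saturated chain carbon bound to a carbonyl carbon gives a 22-fold higher number from compound 3 to compound 4 (1.35 log units; beyond the scatter) and is the first step in the set that removes the sulfur, showing that the low number of compound 3 does not survive this change. The same entering group gives a 3.2-fold higher number from compound 1 to compound 4 (0.51 log units; beyond the scatter) against (1,3-benzoxazol-2-yl)sulfanyl, while a 2.0-fold higher number from compound 2 to compound 4 (0.29 log units; within the scatter) remains within the scatter against (1,3-benzothiazol-2-yl)sulfanyl, so in this assay 4-methylpiperazin-1-yl matches only the benzothiazole-bearing group and stays clear of the other two. No measurement at hand accounts for the size of these steps.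

Compound 4 loses the sulfur and the five-membered aromatic ring at once, so the compounds shown leave open which of the two losses carries the step. A 1-methyl-1H-tetrazol-5-yl group joined through an oxygen or an amine nitrogen, or a morpholine ring or an open-chain dimethylamino group on the same chain carbon, would begin to separate them.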